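A few compounds are considered here, and "the series" means these few. Any claim that something is new, unique, unknown or untested is made for them only; others in the source may bear on it.

Measured compounds:
Compound 1, `Oc1cccc(-c2cc(-c3ccsc3)cc(-c3ccccc3O)n2)c1`: "not determined" (no result reported).
Compound 2, `Oc1cccc(-c2cc(-c3ccsc3)cc(-c3cccc(O)c3)n2)c1`: 4.5%.
Compound 3, `Oc1ccc(-c2cc(-c3ccsc3)cc(-c3cccc(O)c3)n2)cc1`: "not determined" (no result reported).

These three compounds share one core and differ only in where the hydroxyl groups sit on the two outer phenyl rings. Among the measured compounds shown here, of the three, compound 2 is the only one with a number; for compound 1 and compound 3 no result was reported, so nothing can be said about how they compare with it. In an assay on isolated protein for inhibition of DNA topoisomerase 1 (Homo sapiens), with a stated time of 30 min, tested at 20 uM (a higher number here means a stronger effect of the compound at the concentration tested, a lower number a weaker effect), compound 2 gives 4.5%, a small read-out at the tested concentration, meaning the compound barely affects the enzyme under these conditions.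

Compound 4, `Oc1cccc(-c2cc(-c3ccco3)cc(-c3cccc(O)c3)n2)c1`, keeps the two 3-hydroxyphenyl groups and changes the five-membered ring: furan-2-yl in place of thiophen-3-yl on an aromatic carbon. For the measured compounds named here, no pair of measured compounds differs in a single place, so there is no measured step to lean on here. With only the value of compound 2 in this assay to go by, and a read-out already near the floor, the exchange of one five-membered heteroaromatic ring for another is expected to move the number by no more than the usual scatter. Compound 4 is therefore estimated at 5%, within a likely range from -5% to 15%. The expected step is a number 0.5 percentage points higher from compound 2 to compound 4 (within the scatter), which is no change beyond the scatter.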

Compound 4, a percentage reported as inhibition, at one concentration (the size of the read-out at that concentration, not a potency): 0%
For compound 4 the middle estimate is 5 percentage points above the measured one; low and high end bracket the measured number.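

In this assay, exchanging thiophen-3-yl for furan-2-yl on the aromatic carbon opposite the ring nitrogen gives a number 4.5 percentage points lower from compound 2 to compound 4 (within the scatter). Among the compounds shown here, this is the first measured step at this position: a sulfur-containing five-membered aromatic ring gives way to an oxygen-containing one of the same heavy-atom count, attached through a different ring carbon, and the read-out does not leave the usual scatter of repeated measurements, so this exchange produces no detectable difference at the one concentration tested. Both read-outs lie close to the bottom of the scale, so the step cannot say how much this position matters for inhibition of the enzyme, and nothing measured here explains the result.

Still open, on these data alone, is whether a quite different group at this place, such as an aminomethyl group, a carboxylic acid or a longer alkyl chain, would give a read-out clearly beyond the scatter. As far as these compounds go, the role of the hydroxyl positions on the outer rings also stays open, as compound 1 and compound 3 have no reported result to compare with compound 2.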